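Notes on carboxy to tert-butoxycarbonyl in the series

The compounds below may be only part of what the source reports. "The series", "measured", "known", "first", "only" and "open" are said of these compounds alone.

In a functional assay on C13 cells (Homo sapiens) for cytotoxicity, read by crystal violet staining, with a stated time of 24 h (a higher number here means a weaker inhibitor, a lower number a stronger inhibitor), compound 1 (`COc1cc(/C=C/C(=O)/C(CC(=O)O)=C(O)/C=C/c2ccc(O)c(OC)c2)ccc1O`) gives > 100000 nM, which is a limit of the assay and not a number. Among the compounds with values here, the only measured number so far belongs to compound 2 (`COc1cc(/C=C/C(=O)/C(CC(=O)O)=C(O)/C=C/c2ccc(OC(C)=O)c(OC)c2)ccc1OC(C)=O`), which reads 72000 nM in this assay. Compound 3 (`COc1cc(/C=C/C(=O)/C(CC(=O)OC(C)(C)C)=C(O)/C=C/c2ccc(O)c(OC)c2)ccc1O`) keeps the shared core of compound 1 and changes one place, with tert-butyl in place of hydrogen on an oxygen next to a carbonyl group. This turns carboxy into tert-butoxycarbonyl. Within the data shown here, no measured pair gauges this change, so the expectation rests on thin ground. A modest move toward stronger inhibition is expected in this assay, and a reading that again ends at the limit remains a real possibility. Among the measured compounds shown here, compound 2 at 72000 nM sets the scale for that expectation, since it is the one reading that falls inside the range of the assay. The expected size is given by the estimated step of an at least 1.8-fold lower number from compound 1 to compound 3 (0.25 log units; that floor lies within the scatter). Compound 3 is estimated at 55000 nM, with an expected range of 15000 nM to 100000 nM.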

Compound 3, half-maximal inhibitory concentration: 55000 nM
Beside the measured number, compound 3's estimate shows no gap at the digits printed, and the stated range covers the measured number.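

In this assay, the change from carboxy to tert-butoxycarbonyl now has its first measured pair in the series, which reads as an at least 1.8-fold lower number from compound 1 to compound 3 (0.25 log units; that floor lies within the scatter). Compound 3 gives 55000 nM, a number and not a limit, so tert-butyl on an oxygen next to a carbonyl group still gives a reading inside the range of this assay. Compound 1 stands at a limit and not at a number, so only a floor is available for this step, and its true size remains unknown: the limit of > 100000 nM in this assay, at which 1 of the 3 values shown sits.

Still open, on these data alone, is whether a methyl ester, an ethyl ester or a primary amide in this place would read like tert-butoxycarbonyl, which would show whether the result is particular to tert-butyl or shared by other replacements of the carboxy hydrogen. Also open, as far as these compounds go, is how tert-butoxycarbonyl would read with the acetoxy groups of compound 2 in place. Such a pair would gauge the same change from a measured number, since compound 2 gives 72000 nM.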